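The compounds below may be only part of what the source reports. "The series", "measured", "known", "first", "only" and "open" are said of these compounds alone.

Compound 1 `Cc1cc(-c2ccccc2)n(/C(N)=N/S(=O)(=O)c2cc(C)c(Cl)cc2SCc2ccc(C(F)(F)F)cc2)n1` gives 16000 nM in a functional assay on MCF7 cells (Homo sapiens) for cytotoxicity, read by MTT assay, with a stated time of 72 h (on this read-out higher numbers stand for weaker inhibition and lower numbers for stronger inhibition), while compound 2 `Cc1cc(-c2ccccc2)n(/C(N)=N/S(=O)(=O)c2cc(C)c(Cl)cc2SCc2ccc(Cl)cc2)n1` gives 108000 nM in this assay. The step of a 6.8-fold lower number from compound 2 to compound 1 (0.83 log units; beyond the scatter) comes from the change (trifluoromethyl in place of chloro on an aromatic carbon), made para to a large group. Compound 3 `Cc1cc(S(=O)(=O)/N=C(\N)n2nccc2-c2ccccc2)c(SCc2ccccc2Cl)cc1Cl` rests on a different core; the difference between the two cores is not broken down here. In this assay compound 3 gives 24000 nM. Compound 4 `Cc1cc(S(=O)(=O)/N=C(\N)n2nccc2-c2ccccc2)c(SCc2ccccc2C(F)(F)F)cc1Cl` carries the change (trifluoromethyl in place of chloro on an aromatic carbon), made ortho to a large group, so it is the same kind of change as in compound 1 rather than the same one. The step from compound 3 to compound 4 in this assay is expected to be a 3.0-fold lower number from compound 3 to compound 4 (0.48 log units; beyond the scatter), a somewhat smaller step, because a 6.8-fold lower number from compound 2 to compound 1 (0.83 log units; beyond the scatter) was measured with the change made para to a large group, whereas in compound 4 the change sits ortho to a large group. Compound 4 is therefore estimated at 8000 nM, between 3000 nM and 30000 nM.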

Compound 4, half-maximal inhibitory concentration: 21000 nM
For compound 4 the middle estimate is 2.6-fold (0.42 log units) below the measured one; the range from low to high includes it.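

In this assay the change from chloro to trifluoromethyl gives a 1.1-fold lower number from compound 3 to compound 4 (0.06 log units; within the scatter), so the larger step seen on the other core does not recur here. The size of this step did not carry over from one core to the other: the same change on two cores in this assay, a 6.8-fold lower number (0.83 log units; beyond the scatter) from compound 2 to compound 1 and a 1.1-fold lower number (0.06 log units; within the scatter) from compound 3 to compound 4, 5.9-fold (0.77 log units) apart, beyond the scatter of two such steps. Going by these compounds alone, with only one pair on each core, this does not show whether the gap comes from the cores themselves or from the place of the change, as the two differ together in these pairs.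

The compounds shown leave open how a methoxy, a nitrile or an amine on that aromatic carbon would read on either core. Also open, going by these compounds, is how the step would read with the change in the same place on both cores.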